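The source may report more compounds than this note shows. Statements on the series, on what has been measured and on what is new or still open speak of the compounds shown alone.

Measured compounds:
- compound 1, `CN1CCN(c2nc(N)c(C(=O)N=C(N)N)nc2Cl)CC1`: "not determined" (no result reported) in an assay for inhibition of acid-sensing ion channel 3 (Homo sapiens), read by patch clamp, tested at 1 uM; on this read-out higher numbers stand for more inhibition at the one concentration tested (going by the name of the read-out) and lower numbers for less inhibition
- compound 2, `NC(N)=NC(=O)c1ncc(-c2ccccc2)nc1N`: 35%

Compound 1, `CN1CCN(c2nc(N)c(C(=O)N=C(N)N)nc2Cl)CC1`, has no number in this assay, so nothing can be said of how it compares. Among the measured compounds shown here, compound 2, `NC(N)=NC(=O)c1ncc(-c2ccccc2)nc1N`, is therefore the only compound with a value: in this assay compound 2 gives 35%. For the measured compounds named here, with one number and one blank, there is no step between measured compounds, and so no measured scale of how a change at the aromatic carbon moves the read-out.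

Compound 3, `NC(N)=NC(=O)c1ncc(-c2ccsc2)nc1N`, differs from compound 2 in one place: thiophen-3-yl in place of phenyl on an aromatic carbon. Both rings are aromatic and of similar size, and no shown step offers a reason for a shift in either direction. The step from compound 2 to compound 3 is therefore expected to stay within the usual scatter, neither clearly up nor clearly down, which gives an expected no change at the digits printed from compound 2 to compound 3 (within the scatter). Compound 3 is accordingly estimated at 35%, with a range from 15% to 55%, an estimate resting on compound 2 alone.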

Compound 3, a percentage reported as inhibition, at one concentration (the size of the read-out at that concentration, not a potency): 23%
Beside the measured number, compound 3's estimate is 12 percentage points above it; low and high end bracket the measured number.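

In this assay, placing thiophen-3-yl in place of phenyl on this aromatic carbon gives a number 12 percentage points lower from compound 2 to compound 3 (beyond the scatter) and so provides the first measured scale for this position. The position therefore distinguishes between two aromatic rings, a six-membered ring of carbon only and a five-membered ring with 1 hetero atom, with the phenyl ring giving the higher read-out of the pair, while compound 3 still reads 23% at the one concentration tested. The data shown offer no measurement that accounts for this drop, so the step records what happens at this carbon and not why it happens.

With only phenyl and thiophen-3-yl compared at this carbon, the compounds shown leave open whether the read-out follows ring size, the sulfur atom or the point of attachment, and how a furan ring, a pyridine ring, thiophen-2-yl or a simple methyl group would read there. Compound 1 carries a ring amine on the shared core but has no number, so nothing can yet be said of how such an amine compares with either aromatic ring.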